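The compounds below may be only part of what the source reports. "The series", "measured", "known", "first", "only" and "open" are said of these compounds alone.

Measured in a functional assay on HCT-116 cells (Homo sapiens) for inhibition, read by CCK-8 assay, with a stated time of 48 h; on this read-out higher numbers stand for weaker inhibition and lower numbers for stronger inhibition:
- compound 1 `CCN1CCN(C(=S)SCC(=O)N(Cc2ccc(OC)cc2)c2cc(OC)c(OC)c(OC)c2)CC1`: 7700 nM
- compound 2 `COc1ccc(CN(C(=O)CSC(=S)N2CCN(C(C)=O)CC2)c2cc(OC)c(OC)c(OC)c2)cc1`: 1370 nM
- compound 3 `COc1ccc(CN(C(=O)CSC(=S)N2CCc3cc(Br)ccc32)c2cc(OC)c(OC)c(OC)c2)cc1`: 8060 nM

Compound 3 at 8060 nM cannot be told apart from compound 1, with a 1.0-fold higher number from compound 1 to compound 3 (0.02 log units; within the scatter). Compound 2 holds the clearly lower number, with a 5.9-fold higher number from compound 2 to compound 3 (0.77 log units; beyond the scatter).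

Next is compound 4 `COc1ccc(CN(C(=O)CSC(=S)N2CCc3cc(OC)ccc32)c2cc(OC)c(OC)c(OC)c2)cc1`, which has methoxy in place of bromo on an aromatic carbon, (methoxy in place of bromo on an aromatic carbon). For the measured compounds named here, no measured step changes this substituent alone. The nearest evidence comes from exchanges of the whole group on the thiocarbonyl carbon, already given above, and from the acetyl for ethyl exchange, a 5.6-fold lower number from compound 1 to compound 2 (0.75 log units; beyond the scatter). These steps are modest at most, and each replaces more of the molecule than the change at hand. Only a small shift in this assay is therefore expected, with no firm direction and probably nothing beyond the scatter.

The expected step is a 1.3-fold lower number from compound 3 to compound 4 (0.13 log units; within the scatter). For compound 4 the estimated value is 6000 nM, with an expected range of 2000 nM to 18000 nM.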

Compound 4, half-maximal inhibitory concentration: 9810 nM
Estimate against measurement, compound 4: 1.6-fold (0.21 log units) below, within the range that was stated.
By their numbers in this assay, from the lowest: compound 2; then compounds 1, 3 and 4 (each within the scatter of the next).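

In this assay, exchanging bromo for methoxy on this aromatic carbon of the fused system does not separate the two compounds (a 1.2-fold higher number from compound 3 to compound 4 (0.09 log units; within the scatter)), so this place shows no measurable response to this pair of groups. Both 5-substituted 2,3-dihydro-1H-indol-1-yl groups remain level with the 4-ethylpiperazin-1-yl group (a 1.3-fold higher number from compound 1 to compound 4 (0.11 log units; within the scatter)), while the 4-acetylpiperazin-1-yl group remains clearly apart (a 7.2-fold higher number from compound 2 to compound 4 (0.85 log units; beyond the scatter)); among the four compounds, the only gap beyond the scatter therefore involves compound 2. No measured evidence bears on the reason for this flat result.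

From the compounds shown here alone, whether an amine or a carboxylic acid on the same aromatic carbon would move the number remains open. Going by these compounds, it is also open whether a longer acyl chain in place of the acetyl group would keep the lower number of compound 2.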